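A few compounds are considered here, and "the series" means these few. Any claim that something is new, unique, unknown or untested is made for them only; others in the source may bear on it.

Compound 1 `O=C(/C=C/c1ccccc1)Nc1nc2ccccc2s1` and compound 2 `O=C(/C=C/c1ccccc1)Nc1nc2ccc(Cl)cc2s1` share one core, while compound 3 `CC(=O)N1N=C(Nc2nc3ccc(C)cc3s2)CC1c1ccc(Cl)cc1` rests on another; the difference between the two cores is not broken down here. In a functional assay on the whole organism (Hindlimb, strain albino) with Mus musculus as the target, in the maximal electroshock model, with a stated time of 0.5 h (on this read-out lower numbers stand for an effect already at smaller amounts and higher numbers for an effect only at larger amounts of compound), compound 1 gives 646 umol/kg and compound 2 gives 425 umol/kg, so that a 1.5-fold higher number from compound 2 to compound 1 (0.18 log units; within the scatter), the change being (hydrogen in place of chloro on an aromatic carbon). In this assay compound 3 gives 25.5 umol/kg, the lowest of the three numbers. Compound 4 `CC(=O)N1N=C(Nc2nc3ccc(C)cc3s2)CC1c1ccccc1` is not yet measured; it differs from compound 3 by hydrogen in place of chloro on an aromatic carbon, the same kind of change as that from compound 2 to compound 1, though there the place was part of a fused or bridged system of two rings, meta to a fused ring and para to a fused ring, whereas here it is para to a large group. Because a 1.5-fold higher number from compound 2 to compound 1 (0.18 log units; within the scatter) stayed within the scatter, the step expected is a 1.3-fold higher number from compound 3 to compound 4 (0.10 log units; within the scatter). In this assay compound 4 is estimated at 32 umol/kg, between 13 umol/kg and 80 umol/kg.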

Compound 4, dose for half-maximal effect: 106 umol/kg
Compound 4: middle estimate off by 3.3-fold (0.52 log units), on the low side; measured number above the stated range.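

Replacing chloro with hydrogen matters more on the core of compound 3 than on the core of compound 1, giving a 4.2-fold higher number from compound 3 to compound 4 (0.62 log units; beyond the scatter) in this assay. The size of the step therefore does not carry over from one core to the other: the same change on two cores in this assay, a 1.5-fold higher number (0.18 log units; within the scatter) from compound 2 to compound 1 and a 4.2-fold higher number (0.62 log units; beyond the scatter) from compound 3 to compound 4, 2.7-fold (0.44 log units) apart, beyond the scatter of two such steps. This rests on a single pair per core, and the chloro sits in a different place in each pair, so the data cannot separate the effect of the core from that of the position or explain the gap.

On these data alone, it remains open whether fluoro, methoxy or an amine in place of the chloro of the 4-chlorophenyl group would give a number close to that of compound 3. As far as these compounds go, it also remains open how the same change would behave on a third core.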